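Three Limits and One Untested Analogue

The source may report more compounds than this note shows. Statements on the series, on what has been measured and on what is new or still open speak of the compounds shown alone.

Compound 1 `COc1ccc(OC(C)C(=O)Nc2ccc3oc(-c4ccncc4)nc3c2)cc1`: > 5000 nM
Compound 2 `COc1ccc(-c2nc3cc(NC(=O)[C@H](C)Oc4ccccc4CN)ccc3o2)cc1`: > 5000 nM
Compound 3 `C[C@H](Oc1cccc(Cl)c1Cl)C(=O)Nc1ccc2oc(C3=CC=NCC3=O)nc2c1`: > 5000 nM

All three compounds were tested in an assay on isolated protein for inhibition of GMP reductase 2 (Homo sapiens), read by spectrophotometry; on this read-out higher numbers stand for weaker inhibition and lower numbers for stronger inhibition. Compound 1 reaches only the limit of the assay, > 5000 nM, and not a number. Compound 2 likewise gives only a limit, > 5000 nM. Compound 3 also stops at a limit, > 5000 nM. So compound 3 stands nowhere in particular among the numbers shown: every value is the same limit, as the limit of > 5000 nM in this assay, at which 3 of the 3 values shown sit, records, and no compound can be called stronger or weaker than another.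

The untested compound 4 `COc1ccc(Cc2nc3cc(NC(=O)[C@H](C)Oc4cccc(Cl)c4Cl)ccc3o2)cc1` differs from compound 3 in one place: a group of 9 heavy atoms (8 carbon, 1 oxygen; one six-membered aromatic ring of carbon only) in place of a group of 7 heavy atoms (5 carbon, 1 nitrogen, 1 oxygen; one six-membered non-aromatic ring with 1 hetero atom), on an aromatic carbon. Among the compounds with values here, no measured pair differs in one place, so no step size is known from this set. With every measured compound sitting at the limit, the expectation for this assay is no change beyond the scatter, and the step from compound 3 to compound 4 is estimated at a step that the limit leaves unreadable from compound 3 to compound 4. Compound 4 is therefore expected to give roughly 6000 nM, with a range from 1500 nM to 25000 nM, most likely reported again as a limit.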

Compound 4, inhibition constant: > 5000 nM
Compound 4 was reported as a limit (the forecaster's own chance of this, stated with the estimate: 80%); the middle value does not contradict the limit.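

Compound 3 and compound 4 both stop at a limit and not a number, so swapping in the 4-methoxybenzyl group gives no step that can be read: the limit of > 5000 nM in this assay, at which 4 of the 4 values shown sit.

The compounds shown leave open whether any of them truly differs from another in this assay, and which structural change would bring a measurable number.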